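The source may report more compounds than this note shows. Statements on the series, on what has been measured and on what is new or still open speak of the compounds shown alone.

In an ADME assay on HOS cells (Homo sapiens) for cytotoxicity (a higher number here means that more compound is tolerated, a lower number that less compound is tolerated), compound 1 `CCN1CCN(c2cccc3nc(CN(C)[C@H]4CCCc5cccnc54)cn23)CC1` gives 3900 nM. Compound 2 `CCCN(Cc1cn2c(N3CCN(C)CC3)cccc2n1)[C@H]1CCCc2cccnc21` gives 6700 nM, within the usual scatter of compound 1, so the two cannot be ranked. Compound 3 `CN1CCN(c2cccc3nc(CN(C)[C@H]4CCCc5cccnc54)[nH]c23)CC1` gives > 5000 nM, which is a limit and not a number. Compound 1 therefore sits among the few numbers available, with no measured value clearly apart from it.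

Compound 4 `CN(C)[C@H]1CCN(c2cccc3nc(CN(C)[C@H]4CCCc5cccnc54)cn23)C1` has not yet been measured. It carries 3-(dimethylamino)pyrrolidin-1-yl in place of 4-ethylpiperazin-1-yl on an aromatic carbon of the core of compound 1 (3-(dimethylamino)pyrrolidin-1-yl in place of 4-ethylpiperazin-1-yl on an aromatic carbon). The two groups hold the same atoms, joined differently, and compound 4 gains one defined stereocentre.

Among the measured compounds shown here, no measured pair isolates a single change, so the expectation rests on little. Compound 2, at 6700 nM, stays within the scatter of compound 1, and on that basis no shift beyond the scatter is expected in this assay. The expected change is a 1.2-fold higher number from compound 1 to compound 4 (0.06 log units; within the scatter). For compound 4 the estimated value is 4500 nM, with an expected range of 2000 nM to 10000 nM.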

Compound 4, half-maximal cytotoxic concentration: 2100 nM
Estimate against measurement, compound 4: 2.1-fold (0.33 log units) above, and the stated range covers the measured number.
By their numbers in this assay, from the lowest: compounds 4, 1 and 2 (each within the scatter of the next, the first and the last beyond it).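

In this assay the series now holds one step that isolates a single change: a 1.9-fold lower number from compound 1 to compound 4 (0.27 log units; within the scatter). On this aromatic carbon, next to the ring nitrogen, 3-(dimethylamino)pyrrolidin-1-yl and 4-ethylpiperazin-1-yl hold the same atoms joined differently, and the exchange cannot be told apart from repeat measurement in this assay. Compound 3 remains a limit and not a number, and it adds nothing to this step: the limit of > 5000 nM in this assay, at which 1 of the 4 values shown sits.

Going by these compounds, how a morpholine, a primary amine or a carboxylic acid would read at this position stays open, as does what the defined stereocentre of compound 4 contributes on its own. The compounds shown also give no single-place step at the amine nitrogen substituent or in the shared core, so those parts of the series cannot yet be read in this assay.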